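This account rests on a few compounds, and the source may have more. Where it says the series, first, only, none or still open, it means among the compounds named here.

For the measured compounds named here, compound 1 `COc1cc(-c2nnc(SCc3cccc(Br)c3)o2)ccc1O` gives 48100 nM in a functional assay on cells (T-cell, Mus musculus, strain BALB/c) for inhibition, read by MTT assay, with stated times of 24 h and 72 h (on this read-out higher numbers stand for weaker inhibition and lower numbers for stronger inhibition), the highest of the three numbers measured so far. Compound 2 `COc1cc(-c2nnc(SCc3cccc([N+](=O)[O-])c3)o2)ccc1O` gives 16000 nM in this assay, and compound 3 `COc1cccc(CSc2nnc(-c3ccc(O)c(OC)c3)o2)c1` gives 7410 nM in this assay. The measured steps are a 3.0-fold lower number from compound 1 to compound 2 (0.48 log units; beyond the scatter) and a 6.5-fold lower number from compound 1 to compound 3 (0.81 log units; beyond the scatter), with a 2.2-fold lower number from compound 2 to compound 3 (0.33 log units; beyond the scatter) between them; each swaps a group at an aromatic carbon. Compound 4 `COc1cc(-c2nnc(SCc3cccc(Br)c3)o2)ccc1OCc1cccc(Br)c1` differs from compound 1 by 3-bromobenzyl in place of hydrogen on an oxygen on an aromatic ring. Going by the values given here, no measured step touches this oxygen, so none bears directly on the step to compound 4. With nothing to point a direction, the number for compound 4 is expected to stay near compound 1, a 1.2-fold lower number from compound 1 to compound 4 (0.08 log units; within the scatter). Compound 4 is therefore estimated at 40000 nM, with a range from 10000 nM to 160000 nM.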

Compound 4, half-maximal inhibitory concentration: 9120 nM
Compound 4: the middle estimate sits 4.4-fold (0.64 log units) above what was measured; measured number below the stated range.
By their numbers in this assay, from the lowest: compounds 3, 4 and 2 (each within the scatter of the next, the first and the last beyond it); then compound 1.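

Replacing the hydrogen on this oxygen with 3-bromobenzyl gives a 5.3-fold lower number from compound 1 to compound 4 (0.72 log units; beyond the scatter) in this assay, so inhibition strengthens rather than being lost when hydroxy becomes (3-bromobenzyl)oxy. The earlier steps shown here changed only a group on an aromatic carbon, whereas this one shows that the oxygen can also carry a group with its own aromatic ring. Nothing available explains this shift.

For the compounds shown here, with only one group tested on this oxygen, it remains open whether a simple methyl, a plain benzyl without bromine or a chain ending in an amine would do the same.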